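A Methyl Removed from the Pyrazine Amide

This account rests on a few compounds, and the source may have more. Where it says the series, first, only, none or still open, it means among the compounds named here.

Compound 3 `Cc1cnc(C(=O)Nc2ccc(Br)c3cccnc23)cn1` carries a 5-methylpyrazin-2-yl group on its carbonyl carbon. In a functional assay on BXPC-3 cells (Homo sapiens) for inhibition, read by MTT assay, with a stated time of 72 h (on this read-out lower numbers stand for stronger inhibition and higher numbers for weaker inhibition), compound 3 gives > 10000 nM, which is a limit of the assay rather than a number. Compound 1 `O=C(Nc1cccc2cccnc12)c1cccnn1` gives > 10000 nM in this assay, again a limit. Compound 2 `O=C(Nc1cccc2cccnc12)c1ncccn1` gives > 10000 nM in this assay, also a limit. Among the measured compounds shown here, the only measured step, a step that the two limits leave unreadable from compound 1 to compound 2, exchanges one ring for another on the carbonyl carbon, and its size cannot be read, since both ends sit at the limit (the limit of > 10000 nM in this assay, at which 3 of the 3 values shown sit). Compound 4 `O=C(Nc1ccc(Br)c2cccnc12)c1cnccn1` is the unmeasured partner of compound 3. The change is hydrogen in place of methyl on an aromatic carbon, so that 5-methylpyrazin-2-yl becomes pyrazin-2-yl. For the measured compounds named here, no measured step touches this methyl, and the one measured step gives no readable size, so nothing suggests that a small change at this position would lift the inhibition out of the limit. Compound 4 is therefore expected to remain at the limit, with an estimated 20000 nM in this assay, between 7000 nM and 60000 nM. The expected step that the limit leaves unreadable from compound 3 to compound 4 is thus no step beyond the scatter.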

Compound 4, half-maximal inhibitory concentration: 7500 nM
Estimate against measurement, compound 4: 2.7-fold (0.43 log units) above; low and high end bracket the measured number.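

In this assay compound 3 gives > 10000 nM, which is a limit and not a number. In this assay compound 4 gives 7500 nM, the only readable number among the compounds shown. The change reads as an at least 1.3-fold lower number from compound 3 to compound 4 (0.12 log units; that floor lies within the scatter); only a floor is known for this step, so losing the methyl may matter little or a great deal. Every other compound shown stops at the same ceiling: the limit of > 10000 nM in this assay, at which 3 of the 4 values shown sit.

From the compounds shown here alone, what remains open is how this ring carbon responds to groups other than methyl and hydrogen: an ethyl group, a methoxy group, a chlorine atom or an amine in the same place would show whether the readable number belongs to hydrogen alone or whether other groups also allow it. Also open, going by these compounds, is what the bromine on the shared core adds, which a pyrazin-2-yl amide carrying hydrogen in place of that bromine would show, since that single change would separate the effect of the bromine from that of the pyrazine ring.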